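Removing the methyl from compound 2: what to expect

The source may report more compounds than this note shows. Statements on the series, on what has been measured and on what is new or still open speak of the compounds shown alone.

This study measures how strongly a set of small amide compounds act in a functional assay on the whole organism for inhibition, with Rattus norvegicus as the target, at a dose of 10 mg/kg by the oral route; on this read-out lower numbers stand for a weaker effect and higher numbers for a stronger effect at the one dose given. Compound 1 `Cc1cc(Cl)cc(C(=O)Nc2nn[nH]n2)n1` gives 100% in this assay. Compound 2 `Cc1ccc(C(=O)Nc2nn[nH]n2)nc1` gives 42%, and compound 3 `Cc1ccc(C(=O)Nc2nn[nH]n2)nc1C` gives 42%. Compound 2 therefore stands level with compound 3, the two being within the scatter of each other, while compound 1 sits well above both, with a gap that is beyond the scatter.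

The change now followed leads from compound 2 to compound 4 `O=C(Nc1nn[nH]n1)c1ccccn1`. Its content is hydrogen in place of methyl on an aromatic carbon. The methyl that leaves sits on a six-membered aromatic ring with one nitrogen, two atoms from the ring nitrogen.

Going by the values given here, only one measured step resembles this change: the step from compound 2 to compound 3, where a methyl was placed on an aromatic carbon, gave no change at the digits printed from compound 2 to compound 3 (within the scatter). That step added a methyl rather than taking one away, and at a different carbon, but it is the nearest guide available, and it suggests a single methyl on this ring does little in this assay. Compound 1 carries a different group, so its higher number does not bear directly on a methyl alone.

On this basis the step from compound 2 to compound 4 is expected to be no change at the digits printed from compound 2 to compound 4 (within the scatter), that is, no change beyond the scatter. Compound 4 is accordingly estimated to give 42% in this assay, within a range from 20% to 65%.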

Compound 4, a percentage reported as inhibition, in the whole organism at one dose (the size of the read-out at that dose, not a potency): 35%
Compound 4: middle estimate off by 7 percentage points, on the high side; the range from low to high includes it.
By their numbers in this assay, from the lowest: compounds 4, 2 and 3 (each within the scatter of the next); then compound 1.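

In this assay, taking the methyl away from this ring carbon, two atoms from the ring nitrogen, gives a number 7 percentage points lower from compound 2 to compound 4 (within the scatter), so the effect at this one dose does not depend on this methyl being present. Going by these compounds alone, until now, the only methyl change on this ring was an addition at a different carbon; this result adds a removal at this position, and that change also stays within the usual scatter of the measurement, so hydrogen and methyl cannot be told apart here. Nothing available explains why this swap leaves the read-out within the scatter.

The compounds shown leave open whether anything other than hydrogen or methyl at this carbon would shift the number, for example an amine, a carboxylic acid or a longer chain. They also leave open whether the same swap would stay as small on a ring carrying other groups, since here it has been followed only on the simplest ring of the set.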